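The source may hold more compounds than are shown below. What is called first, only, known or untested is meant among the compounds shown, and "the series" means these compounds.

Two compounds that share a core have been examined in a functional assay on MCF7 cells (Homo sapiens) for inhibition, read by colorimetric assay and MTT assay, with a stated time of 72 h; on this read-out lower numbers stand for stronger inhibition and higher numbers for weaker inhibition. Compound 1 `COc1ccc(-c2cc(NC(=S)NNC(=O)c3ccc(C)cc3)cs2)cc1` gives 40000 nM in this assay. Compound 2 `COc1cc(C(=O)NNC(=S)Nc2csc(-c3ccccc3)c2)cc(OC)c1OC` gives 43000 nM in this assay. Compound 2 stands at the highest of the two numbers, with compound 1 the nearest to it by a gap that lies within the scatter, so neither can be called the more active of the pair. Compound 3 `COc1cc(C(=O)NNC(=S)Nc2csc(-c3ccc(C)cc3)c2)cc(OC)c1OC` differs from compound 2 by methyl in place of hydrogen on an aromatic carbon. Within the data shown here, no measured pair shows this change on its own, so its effect cannot be read from the two values at hand. Since both measured compounds sit close together in this assay, the expected step is a 1.1-fold lower number from compound 2 to compound 3 (0.03 log units; within the scatter), none beyond the scatter. The estimate for compound 3 in this assay is 40000 nM, within a range from 15000 nM to 100000 nM.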

Compound 3, half-maximal inhibitory concentration: 31000 nM
For compound 3 the middle estimate is 1.3-fold (0.11 log units) above the measured one; the range from low to high includes it.
By their numbers in this assay, from the lowest: compounds 3, 1 and 2 (each within the scatter of the next).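

Among these compounds, the change from phenyl to 4-methylphenyl, on an aromatic carbon para to a large group, gives in this assay a 1.4-fold lower number from compound 2 to compound 3 (0.14 log units; within the scatter) and so provides the first direct reading of this change on its own. It shows that this position carries one added carbon with no shift beyond the scatter, and all three numbers remain within the scatter of their neighbours in the order. Nothing at hand gives a reason for this result.

What the compounds shown leave open is whether a group of another kind at this same place, such as an amine or a carboxylic acid, would move the number beyond the scatter. Also open, going by these compounds, is whether a longer chain there, such as ethyl or propyl, would do so.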